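A few compounds are considered here, and "the series" means these few. Any claim that something is new, unique, unknown or untested is made for them only; others in the source may bear on it.

Measured compounds:
Compound 1, `Cn1cnc2c(Sc3ccc(F)cc3)ncnc21`, in an assay on isolated protein for inhibition of Ca2+/calmodulin-dependent protein kinase II (CaM kinase II) (Rattus norvegicus), tested at 30 uM (on this read-out lower numbers stand for less inhibition and higher numbers for more inhibition at the one concentration tested (going by the name of the read-out)), gives 5%.
Compound 2, `Fc1ccc(Cn2cnc3c(Sc4ccccc4)ncnc32)cc1`, in this assay gives 0%.

Both numbers sit at the low end of what this assay can report, so neither compound does much at the single concentration used. Compound 2 has the lower of the two numbers, but its gap to compound 1 is within the usual scatter of repeated measurements, so the two compounds cannot really be told apart on this evidence.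

Compound 3, `Fc1ccc(Cn2cnc3c(Sc4ccc(F)cc4)ncnc32)cc1`, has not yet been tested in this assay. It differs from compound 2 in one place: fluoro in place of hydrogen on an aromatic carbon. Compound 1 already carries fluoro on that ring, with hydrogen instead of the substituted benzyl group elsewhere, and it too shows almost no effect. Since both measured compounds hover near zero, the step from compound 2 to compound 3 is expected to be small, in either direction, and not beyond the scatter, giving an estimated a number 3 percentage points higher from compound 2 to compound 3 (within the scatter). Compound 3 is therefore expected to give about 3% in this assay, within a range from -8% to 15%.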

Compound 3, a percentage reported as inhibition, at one concentration (the size of the read-out at that concentration, not a potency): 0%
For compound 3 the middle estimate is 3 percentage points above the measured one; the measured number falls inside the stated range.
By their numbers in this assay, from the lowest: compounds 2, 3 and 1 (each within the scatter of the next).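

Among the compounds shown here, this position, on an aromatic carbon para to a large group, can now be read directly for the first time: in this assay, fluoro in place of hydrogen gives no change at the digits printed from compound 2 to compound 3 (within the scatter). The other listed change, 4-fluorophenyl in place of hydrogen on a saturated chain carbon bound to an aromatic nitrogen, gives a number 5 percentage points lower from compound 1 to compound 3 (within the scatter), so neither single change brings out inhibition that can be told from the scatter. Nothing available explains why these compounds stay at the low end of the read-out.

With numbers this low, a step to a lower number would hardly show, so these steps say little about whether fluoro or the 4-fluorophenyl group matters in a compound with a higher number. Going by these compounds, it remains open whether an amine or a carboxylic acid at the same aromatic carbon, or a longer chain on the aromatic nitrogen, would raise the number in this assay beyond the scatter.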